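A few compounds are considered here, and "the series" means these few. Any claim that something is new, unique, unknown or untested is made for them only; others in the source may bear on it.

Working notes on the series, read in a functional assay on MCF7 cells (Homo sapiens) for inhibition, read by MTT assay, with a stated time of 48 h, tested at 10 uM; a higher number here means more inhibition of growth at the concentration tested, a lower number less inhibition of growth. Compound 1 `Cc1cc(=O)c2c(O)cc(OCc3ccc([N+](=O)[O-])cc3)c([C@H]3CCN(C)C[C@H]3O)c2o1` gives 39%, compound 2 `Cc1oc2c([C@H]3CCN(C)C[C@H]3O)c(O)cc(O)c2c(=O)c1C(O)c1ccc(F)c(Br)c1` gives 14%, and compound 3 `Cc1oc2c([C@H]3CCN(C)C[C@H]3O)c(O)cc(O)c2c(=O)c1C(O)c1c(Cl)cccc1Cl` gives 33%. Compound 3 lies within the scatter of compound 1 and clearly above compound 2, so only compound 2 separates from it on these numbers.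

Compound 4 `CCOc1ccc(Br)c(C(O)c2c(C)oc3c([C@H]4CCN(C)C[C@H]4O)c(O)cc(O)c3c2=O)c1` has not been measured. Its difference from compound 3 is 2-bromo-5-ethoxyphenyl in place of 2,6-dichlorophenyl on a saturated chain carbon bound to an aromatic carbon and an oxygen on a saturated carbon.

For the measured compounds named here, one measured step bears on this place: a number 19 percentage points higher from compound 2 to compound 3 (beyond the scatter), with 2,6-dichlorophenyl in place of 3-bromo-4-fluorophenyl. That single step shows that a swap here can move the number beyond the scatter, but it gives no direction for the entering group, which has not been tested. The entering group shares its bromine with compound 2, at 14%, so the expectation leans slightly low and no more. The step expected in this assay is a number 7 percentage points lower from compound 3 to compound 4 (within the scatter), with nothing beyond the scatter expected. For compound 4 the estimated value is 26%, with an expected range of 10% to 42%.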

Compound 4, percent growth inhibition at one concentration: 9%
Compound 4: middle estimate off by 17 percentage points, on the high side; the measured number lies below the stated range.
By their numbers in this assay, from the lowest: compounds 4 and 2 (each within the scatter of the next); then compounds 3 and 1 (each within the scatter of the next).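

At the saturated chain carbon bound to an aromatic carbon and an oxygen on a saturated carbon, the aryl group can lower the growth inhibition as well as raise it: a number 24 percentage points lower from compound 3 to compound 4 (beyond the scatter), while the two bromine-bearing groups do not separate, with a number 5 percentage points lower from compound 2 to compound 4 (within the scatter). 2,6-Dichlorophenyl therefore stands clear of both 2-bromo-5-ethoxyphenyl and 3-bromo-4-fluorophenyl, and the entering ethoxy group, with its added hydrogen-bond acceptor, leaves the number within the scatter of compound 2, which has neither that group nor that acceptor. Among compounds 2, 3 and 4 the two groups carrying bromine sit together and the group carrying chlorine sits apart, a pattern resting on these three compounds alone, and no measurement here offers an explanation for it.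

Still open, on these data alone, is whether the separation of compound 3 follows the chlorine atoms themselves or the arrangement of substituents on the ring, as the halogen and its place change together in these compounds. Also open, as far as these compounds go, is how an unsubstituted phenyl, a phenyl carrying an amine or a carboxylic acid, or a plain alkyl chain would read at this place.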